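The source may hold more compounds than are shown below. What is called first, only, known or untested is meant among the compounds shown, and "the series" means these compounds.

Measured compounds:
compound 1 `COc1cccc(CNC(=O)c2cn(CCN(C)C)c3cc(-c4cn[nH]c4)ccc23)c1` — 0.333 h
compound 2 `COc1cccc(CNC(=O)c2cn(C)c3nc(-c4cn[nH]c4)ccc23)c1` — 0.217 h
compound 3 `COc1cccc(CN(C)C(=O)c2c[nH]c3cc(-c4cn[nH]c4)ccc23)c1` — 0.217 h

All three were tested in an in vitro ADME assay on microsomes from liver (Homo sapiens) for metabolic stability; a lower number here means that the compound disappears faster, a higher number that the compound lasts longer. Compound 1 gives 0.333 h, compound 2 gives 0.217 h and compound 3 gives 0.217 h. These numbers lie within the usual scatter of one another, so none stands apart and compound 1 is simply one of a tight group. Compound 4 `COc1cccc(CNC(=O)c2c[nH]c3cc(-c4cn[nH]c4)ccc23)c1` has not yet been measured. It differs from compound 1 in one place: hydrogen in place of 2-(dimethylamino)ethyl on an aromatic nitrogen. Going by the values given here, no pair of measured compounds differs in only this place, so nothing here shows what the change does on its own. The expected step is a 1.3-fold lower number from compound 1 to compound 4 (0.12 log units; within the scatter), nothing beyond the scatter. For compound 4 the estimated half-life is 0.25 h, within a range from 0.12 h to 0.5 h.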

Compound 4, half-life in the Homo sapiens assay: 0.417 h
Compound 4: the middle estimate sits 1.7-fold (0.22 log units) below what was measured; measured number inside the range.
By their numbers in the Homo sapiens assay, from the lowest: compounds 2, 3, 1 and 4 (each within the scatter of the next).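

In the Homo sapiens assay, hydrogen in place of 2-(dimethylamino)ethyl on the aromatic nitrogen gives a 1.3-fold higher number from compound 1 to compound 4 (0.10 log units; within the scatter), and hydrogen in place of methyl on the amide-type nitrogen gives a 1.9-fold higher number from compound 3 to compound 4 (0.28 log units; within the scatter), so neither change stands out from the scatter. With 2-(dimethylamino)ethyl on that aromatic nitrogen, in a physicochemical assay for solubility, at pH 5.5 (on this read-out lower numbers stand for lower solubility and higher numbers for higher solubility), compound 1 gives >= 100000 nM, a limit of the assay and not a number. With hydrogen there, in the physicochemical assay compound 4 gives <= 10 nM, also a limit.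

On these data alone, the true size of the gap between compound 1 and compound 4 stays open. So does what a 2-hydroxyethyl chain or a carboxylic acid on this aromatic nitrogen would give in the physicochemical assay.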